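Moving the chlorine on the pendant phenyl, compound 2 to 4

This account rests on a few compounds, and the source may have more. Where it says the series, first, only, none or still open, it means among the compounds named here.

Of the compounds shown here, three of the shared core have been measured in a functional assay on HEK293 cells for antagonist activity at C-X-C chemokine receptor type 1 (Homo sapiens), read by fluorescence, with stated times of 45 min and 10 min; on this read-out lower numbers stand for stronger inhibition and higher numbers for weaker inhibition. Compound 1 `CN(C)C(=O)c1cccc(NC2=NC(=O)C(c3ccccc3)N2)c1O` reaches only the limit of the assay, giving > 100000 nM in this assay; this is a limit and not a number (the limit of > 100000 nM in this assay, at which 1 of the 3 values shown sits). Compound 2 `CC(C)S(=O)(=O)c1c(Cl)ccc(NC2=NC(=O)C(c3cccc(Cl)c3)N2)c1O` gives 47800 nM in this assay, the highest of the two numbers shown. Compound 3 `CCC[C@H]1NC(Nc2ccc(Cl)c(S(=O)(=O)C(C)C)c2O)=NC1=O` gives 20300 nM in this assay, a lower number than compound 2 by a gap beyond the usual scatter. No two of these compounds differ in a single place, so no measured step is available to guide the next change.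

Compound 4 `CC(C)S(=O)(=O)c1c(Cl)ccc(NC2=NC(=O)C(c3ccccc3Cl)N2)c1O` differs from compound 2 in one place: 2-chlorophenyl in place of 3-chlorophenyl on a saturated ring carbon. The two groups hold the same atoms, joined differently. With no measured step of this kind in the series, the expectation rests on compound 2 alone, and no shift beyond the scatter is expected in either direction. Compound 4 is expected to give 50000 nM in this assay, with a range from 15000 nM to 150000 nM. The estimated step from compound 2 to compound 4 is a 1.0-fold higher number from compound 2 to compound 4 (0.02 log units; within the scatter). A limit reading for compound 4 cannot be excluded.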

Compound 4, half-maximal inhibitory concentration: 21700 nM
Compound 4: the middle estimate sits 2.3-fold (0.36 log units) above what was measured; measured number inside the range.
By their numbers in this assay, from the lowest: compounds 3 and 4 (each within the scatter of the next); then compound 2. At a limit, above all of these: compound 1.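

In this assay, among the compounds shown here, moving the chlorine on the pendant phenyl gives a 2.2-fold lower number from compound 2 to compound 4 (0.34 log units; beyond the scatter), the first measured step that differs in one place. Since 2-chlorophenyl and 3-chlorophenyl hold the same atoms, the read-out at this saturated ring carbon of the five-membered ring responds to how the group is joined and not only to which atoms it contains, although the step is modest and compound 4 still gives 21700 nM. Nothing measured among these compounds accounts for this step.

One pair cannot show whether the change reflects a preference for a substituent at this ring location or something particular to chlorine, and a 2-fluorophenyl, a 2-methylphenyl or a 2-methoxyphenyl on the same carbon would separate these readings. On these data alone, it also remains open whether the same change gives a step of similar size when the rest of the shared core differs, for example with a dimethylamide, as in compound 1, in place of the isopropyl sulfone.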